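Cytotoxicity series: amide aryl swap from compound 3 to compound 4

This account rests on a few compounds, and the source may have more. Where it says the series, first, only, none or still open, it means among the compounds named here.

In an ADME assay on Vero cells (Chlorocebus sabaeus) for cytotoxicity, read by resazurin assay, with a stated time of 3 days (a lower number here means a stronger inhibitor, a higher number a weaker inhibitor), compound 3 `CCN(CC)c1cc2[nH]c(C3CCCCC3)nc2cc1NC(=O)c1ccc(F)cc1` gives only a limit, > 100 ug/mL. Compound 1 `CCN(CC)c1cc2[nH]c(C3CCCCC3)nc2cc1NC(=O)c1cnccn1` likewise gives a limit in this assay, > 100 ug/mL. Compound 2 `CCCCOC(=O)Nc1cc2nc(C3CCCCC3)[nH]c2cc1N(C)C` also gives a limit there, > 100 ug/mL. All three values thus sit on (the limit of > 100 ug/mL in this assay, at which 3 of the 3 values shown sit), and the step that the two limits leave unreadable from compound 1 to compound 3 cannot be read from the two limits. Compound 4 `C=Cc1cccc(C(=O)Nc2cc3nc(C4CCCCC4)[nH]c3cc2N(CC)CC)c1` differs from compound 3 by 3-vinylphenyl in place of 4-fluorophenyl on a carbonyl carbon. The only measured step bearing on an aryl swap at this carbonyl, a step that the two limits leave unreadable from compound 1 to compound 3, has no readable size, so nothing shown points to a change in this assay beyond the scatter. Compound 4 is expected to sit at the limit again, with an estimated step of a number no higher from compound 3 to compound 4 (the limit leaves the size open). The estimate for compound 4 is 100 ug/mL, from 50 ug/mL to 200 ug/mL.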

Compound 4, half-maximal inhibitory concentration: > 100 ug/mL
Compound 4: only a limit was reported; the forecaster's own chance of this, stated with the estimate: 80%; the middle value sits exactly at the limit.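

Compound 4 gives > 100 ug/mL, which is a limit. The steps from compound 1 and compound 3 to compound 4 in this assay cannot be read: the limit of > 100 ug/mL in this assay, at which 4 of the 4 values shown sit.

The compounds shown leave open at what concentration any of them reaches half-maximal inhibition.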